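Shifting the Chlorine on the Phenyl Bound to Sulfur

The source may report more compounds than this note shows. Statements on the series, on what has been measured and on what is new or still open speak of the compounds shown alone.

Two compounds share a core carrying a side chain that ends in a halogenated phenyl on sulfur. Compound 1 `Cn1c(=O)c2c(nc(CSc3cccc(Br)c3)n2C)n(C)c1=O` gives 4900 nM in an in vitro assay on cells for inhibition of Amine oxidase [flavin-containing] B (Homo sapiens), read by fluorescence and spectrophotometry, with a stated time of 20 min; a lower number here means a stronger inhibitor, a higher number a weaker inhibitor. Compound 2 `Cn1c(=O)c2c(nc(CSc3cccc(Cl)c3)n2C)n(C)c1=O`, in which chloro replaces bromo on an aromatic carbon, gives 6120 nM in this assay; the step of a 1.2-fold higher number from compound 1 to compound 2 (0.10 log units; within the scatter) stays within the scatter, so the two numbers cannot be ordered. Compound 2 thus stands alongside compound 1 on the two numbers available, with nothing separating them beyond the usual scatter.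

Compound 3 `Cn1c(=O)c2c(nc(CSc3ccc(Cl)cc3)n2C)n(C)c1=O` is not yet measured. It differs from compound 2 by 4-chlorophenyl in place of 3-chlorophenyl on a sulfur; the atoms are the same and only the place of the chlorine on the phenyl changes. Going by the values given here, no measured step moves a substituent around a ring: the single step at hand, a 1.2-fold higher number from compound 1 to compound 2 (0.10 log units; within the scatter), swaps one halogen for another on an aromatic carbon and shows no change beyond the scatter. It bears on compound 3 only loosely and gives no direction. The step expected in this assay is a 1.0-fold lower number from compound 2 to compound 3 (0.01 log units; within the scatter), none beyond the scatter. Compound 3 is estimated at 6000 nM in this assay, with a range from 2000 nM to 18000 nM.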

Compound 3, half-maximal inhibitory concentration: 6910 nM
Compound 3: the middle estimate sits 1.2-fold (0.06 log units) below what was measured; low and high end bracket the measured number.
By their numbers in this assay, from the lowest: compounds 1, 2 and 3 (each within the scatter of the next).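

In this assay, going by these compounds alone, 4-chlorophenyl in place of 3-chlorophenyl on a sulfur gives the first reading of a change in which the atoms stay the same and only the place of the chlorine differs: a 1.1-fold higher number from compound 2 to compound 3 (0.05 log units; within the scatter). Here, the place of the chlorine on the phenyl does not separate compound 2 from compound 3. The step that changes both the halogen and its place gives a 1.4-fold higher number from compound 1 to compound 3 (0.15 log units; within the scatter), so even with both changes together the three compounds remain inseparable in this read-out, and no evidence is at hand that bears on this result.

The three compounds all carry a single halogen on the phenyl, so they leave open whether any other group on that ring, such as an amine or a carboxylic acid in place of the halogen, would give a step beyond the scatter. On these data alone, how a plain phenyl with no halogen would read, and what a longer chain on the sulfur in place of the phenyl would do, also remain open.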